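Replacing a Methylphenyl Arm with a Dichlorophenylethenyl Chain

This account rests on a few compounds, and the source may have more. Where it says the series, first, only, none or still open, it means among the compounds named here.

Compound 1 `COC(=O)/C=C/c1cccc(N(Cc2ccc(-c3cccc(C)c3)cc2)C(=O)C2CCCCC2)c1`: 109 nM
Compound 2 `COC(=O)/C=C/c1cccc(N(Cc2ccc(-c3cccc(C)c3)cc2)C(=O)C(C)C)c1`: 163 nM
Compound 3 `COC(=O)/C=C/c1cccc(N(Cc2ccc(-c3ccc(N(C)C)cc3)cc2)C(=O)C(C)C)c1`: 57 nM

In an assay on isolated protein with Bile acid receptor (Homo sapiens) as the target (a lower number here means that less compound is needed, a higher number that more compound is needed for the effect), compound 1 holds the second highest of the three numbers, and both compound 2 and compound 3 lie within the scatter of it. Compound 4 `COC(=O)/C=C/c1cccc(N(Cc2ccc(/C=C/c3c(Cl)cccc3Cl)cc2)C(=O)C2CCCCC2)c1` differs from compound 1 in one place: 2-(2,6-dichlorophenyl)ethenyl in place of 3-methylphenyl on an aromatic carbon. Among the measured steps, only the one from compound 2 to compound 3 changes a group on an aromatic carbon, and there the 3-methylphenyl was replaced by 4-(dimethylamino)phenyl: a 2.9-fold lower number from compound 2 to compound 3 (0.46 log units; beyond the scatter). The other step, a 1.5-fold higher number from compound 1 to compound 2 (0.17 log units; within the scatter), concerns the carbonyl carbon and does not bear on this change. Going by the values given here, the entering 2-(2,6-dichlorophenyl)ethenyl group has no counterpart among the measured compounds, so no direction can be read from them. Compound 4 is therefore expected to give about 100 nM, with a range from 35 nM to 300 nM. The step this estimate means, a 1.1-fold lower number from compound 1 to compound 4 (0.04 log units; within the scatter), is expected to stay within the scatter.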

Compound 4, half-maximal effective concentration: 150 nM
Estimate against measurement, compound 4: 1.5-fold (0.18 log units) below, within the range that was stated.
By their numbers in this assay, from the lowest: compounds 3, 1, 4 and 2 (each within the scatter of the next, the first and the last beyond it).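

In this assay, replacing 3-methylphenyl with 2-(2,6-dichlorophenyl)ethenyl gives a 1.4-fold higher number from compound 1 to compound 4 (0.14 log units; within the scatter). Until now, only substituted phenyl groups had been seen at this position, para to a large group, and this result shows that it also accepts a chain with a double bond outside the aromatic ring and two chlorine atoms. No measurement here explains why the number stays within the scatter. The compounds shown leave open whether the double bond or the chlorine atoms matter, which a plain 2-phenylethenyl chain or a saturated 2-phenylethyl chain could help to separate.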